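The source may hold more compounds than are shown below. What is called first, only, known or untested is meant among the compounds shown, and "the series" means these compounds.

Measured in a functional assay on A-375 cells (Homo sapiens) for inhibition, read by CCK-8 assay, with a stated time of 72 h, tested at 8 uM; a higher number here means more inhibition of growth at the concentration tested, a lower number less inhibition of growth:
compound 1 `COc1ccc(SCc2ccc(C(=O)Nc3ccccc3N)cc2)cc1`: 81.8%
compound 2 `Nc1ccccc1NC(=O)c1ccc(CSc2ccc(Br)cc2)cc1`: 6.17%

Of the two, compound 2 stands lowest, and compound 1 lies far above it, beyond the scatter. Compound 3 `CC(C)(C)c1ccc(SCc2ccc(C(=O)Nc3ccccc3N)cc2)cc1` keeps the shared core and alters the group that separates those two: tert-butyl in place of bromo on an aromatic carbon. In words, it has tert-butyl in place of bromo on an aromatic carbon.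

Within the data shown here, only one measured step bears on this change: a number 75.6 percentage points lower from compound 1 to compound 2 (beyond the scatter), a large one, with bromo in place of methoxy. Among the measured compounds shown here, it shows that a swap at this place can move the number widely, but no measured compound carries tert-butyl, so it fixes no direction. An upward move is expected, mainly because compound 2 gives 6.17% and has little room to fall. The expected step, of moderate size and uncertain, is a number 23.8 percentage points higher from compound 2 to compound 3 (beyond the scatter). For compound 3 the estimate is 30%, with an expected range of 5% to 70%.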

Compound 3, percent growth inhibition at one concentration: 33.1%
Compound 3: middle estimate off by 3.1 percentage points, on the low side, and the stated range covers the measured number.
By their numbers in this assay, from the lowest: compound 2; then compound 3; then compound 1.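

With a third group at this position, the picture in this assay goes beyond a single swap. Tert-butyl in place of bromo brings a number 26.9 percentage points higher from compound 2 to compound 3 (beyond the scatter) and shows that the low reading of compound 2 is not shared by every group that replaces methoxy, yet the comparison with methoxy gives a number 48.7 percentage points lower from compound 1 to compound 3 (beyond the scatter) and so neither replacement shown reaches the level of compound 1. Nothing at hand explains this order of the three groups.

On these data alone, it remains open whether an amine or a carboxylic acid at this position would read above or below these three groups. As far as these compounds go, it is equally open whether ethoxy, a longer chain ending in the same oxygen link to the ring, would hold the level of compound 1.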